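Swapping amino for a phosphorus group on the shared core

The source may report more compounds than this note shows. Statements on the series, on what has been measured and on what is new or still open speak of the compounds shown alone.

In a functional assay on MCF7 cells (Homo sapiens) for antiproliferative activity, read by MTT assay, with stated times of 24 h and 72 h (a higher number here means a weaker inhibitor, a lower number a stronger inhibitor), compound 1 (`COc1ccc([C@@H]2[C@H](Oc3ccccc3)C(=O)N2c2cc(OC)c(OC)c(OC)c2)cc1`) gives 35000 nM, and compound 2 (`COc1ccc([C@@H]2[C@H](Oc3ccccc3)C(=O)N2c2cc(OC)c(OC)c(OC)c2)cc1N`) gives 12200 nM, the lower of the two numbers. Compound 3 (`COc1ccc([C@@H]2[C@H](Oc3ccccc3)C(=O)N2c2cc(OC)c(OC)c(OC)c2)cc1OP(=O)(O)O`) replaces the amino group of compound 2 on an aromatic carbon: a group of 5 heavy atoms (4 oxygen, 1 phosphorus; no ring) in place of one nitrogen atom, on an aromatic carbon. Within the data shown here, only one measured step bears on this site, the modest 2.9-fold lower number from compound 1 to compound 2 (0.46 log units; beyond the scatter), where amino replaced hydrogen. That step does not test the entering group, so no direction is favoured, and the expected change is small: a 1.0-fold lower number from compound 2 to compound 3 (0.01 log units; within the scatter). Compound 3 is expected at 12000 nM, within an estimated range of 2500 nM to 45000 nM.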

Compound 3, half-maximal inhibitory concentration: 42000 nM
Compound 3: the middle estimate sits 3.5-fold (0.54 log units) below what was measured; measured number inside the range.
By their numbers in this assay, from the lowest: compound 2; then compounds 1 and 3 (each within the scatter of the next).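

In this assay the aromatic carbon ortho to a methoxy group proves sensitive to which group enters: the phosphorus group gives a 3.4-fold higher number from compound 2 to compound 3 (0.54 log units; beyond the scatter) and so does not keep what amino gained. Set against hydrogen, the same group gives a 1.2-fold higher number from compound 1 to compound 3 (0.08 log units; within the scatter) and this lies within the scatter, so the two cannot be told apart at this position. Nothing available explains the difference between amino and the phosphorus group. From the compounds shown here alone, whether a hydroxyl group or a carboxylic acid at this carbon would behave like amino or like the phosphorus group remains open.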